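Acyl variation on the acetamido series at the potassium channel

This account rests on a few compounds, and the source may have more. Where it says the series, first, only, none or still open, it means among the compounds named here.

Measured so far:
compound 1 `CC(=O)Nc1c(C(O)(C(F)(F)F)C(F)(F)F)ccc2ccccc12` — 18 nM
compound 2 `CCCC(=O)Nc1c(C(O)(C(F)(F)F)C(F)(F)F)ccc2ccccc12` — 131 nM
compound 3 `CCC(CC)C(=O)Nc1c(C(O)(C(F)(F)F)C(F)(F)F)ccc2ccccc12` — 4340 nM

In an assay on LtK cells with ATP-sensitive inward rectifier potassium channel 11 (Homo sapiens) as the target (on this read-out lower numbers stand for an effect already at smaller amounts and higher numbers for an effect only at larger amounts of compound), compound 1 gives the lowest of the three numbers. Its nearest neighbour is compound 2, with a 7.3-fold higher number from compound 1 to compound 2 (0.86 log units; beyond the scatter). The largest gap is to compound 3, with a 240-fold higher number from compound 1 to compound 3 (2.38 log units; beyond the scatter). Between the two larger acyl groups the step is a 33-fold higher number from compound 2 to compound 3 (1.52 log units; beyond the scatter), so each growth of the chain on the carbonyl carbon has so far gone with a higher number.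

Compound 4 `O=C(Nc1c(C(O)(C(F)(F)F)C(F)(F)F)ccc2ccccc12)C1CCC1` is not yet measured. It differs from compound 1 as follows: cyclobutyl in place of methyl on a carbonyl carbon. The cyclobutyl group is branched at the carbon bound to the carbonyl, as pentan-3-yl is in compound 3, but it carries fewer carbons than pentan-3-yl and is tied into a four-membered ring. The steps from compound 1 to compound 2 and to compound 3 both bear on this change and both point upward; cyclobutyl sits between propyl and pentan-3-yl in size, so a step of intermediate size is expected in this assay, upward, beyond the scatter.

For compound 4 the expected value is 500 nM, with a range of 120 nM to 2500 nM, which would mean an estimated step of a 28-fold higher number from compound 1 to compound 4 (1.44 log units; beyond the scatter).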

Compound 4, half-maximal effective concentration: 45 nM
Compound 4: the middle estimate sits 11-fold (1.05 log units) above what was measured; measured number below the stated range.
By their numbers in this assay, from the lowest: compound 1; then compound 4; then compound 2; then compound 3.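

Cut at the carbonyl carbon, the series now shows that a larger acyl group need not bring a large rise in this assay: replacing methyl with cyclobutyl gives only a 2.5-fold higher number from compound 1 to compound 4 (0.40 log units; beyond the scatter), although compound 1 still holds the lowest number. Compound 4 also goes against the earlier rise with each growth of the chain, since cyclobutyl in place of propyl gives a 2.9-fold lower number from compound 2 to compound 4 (0.46 log units; beyond the scatter), so the open-chain ordering of compound 1, compound 2 and compound 3 does not extend to the ring. Branching at the carbon bound to the carbonyl does not by itself go with a number as high as that of compound 3, as the change from pentan-3-yl to cyclobutyl gives a 96-fold lower number from compound 3 to compound 4 (1.98 log units; beyond the scatter).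

Nothing at hand accounts for the difference between the ring and the open chains. Going by these compounds, it remains open whether cyclopropyl or cyclopentyl on the carbonyl carbon would stay close to compound 4 or move towards compound 3, and how an amine or a hydroxyl group on the cyclobutyl ring would read.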